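This account rests on a few compounds, and the source may have more. Where it says the series, first, only, none or still open, it means among the compounds named here.

Compound 3 `CCCCCCCCCCCCCCCCCCNC(=O)[C@H]1CSC(c2ccc(Br)cc2)N1` gives 13800 nM in a functional assay on DU-145 cells (Homo sapiens) for antiproliferative activity, read by sulforhodamine B assay (a lower number here means a stronger inhibitor, a higher number a weaker inhibitor), the higher of the two numbers in hand. Its nearest neighbour is compound 2 `CCCCCCCCCCCCCCCCCCNC(=O)[C@H]1CSC(c2c[nH]c3ccccc23)N1`, which in this assay gives 8900 nM, and the step of a 1.6-fold higher number from compound 2 to compound 3 (0.19 log units; within the scatter) does not separate the two. Compound 1 `CCCCCCCCCCCCCCCCCCNC(=O)[C@H]1CSC(C2CCCCC2)N1` reaches only the limit of this assay, > 20000 nM. From it, the steps of an at least 2.2-fold lower number from compound 1 to compound 2 (0.35 log units; beyond the scatter) and an at least 1.4-fold lower number from compound 1 to compound 3 (0.16 log units; that floor lies within the scatter) are read against that limit (the limit of > 20000 nM in this assay, at which 1 of the 3 values shown sits).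

Compound 4 `CCCCCCCCCCCCCCCCCCNC(=O)[C@H]1CSC(c2ccc(C#N)cc2)N1` differs from compound 3 by cyano in place of bromo on an aromatic carbon. No measured step alters a substituent on the aromatic ring; the steps measured so far exchange the whole group on the saturated ring carbon, and among these the exchange of aromatic groups, a 1.6-fold higher number from compound 2 to compound 3 (0.19 log units; within the scatter), stayed within the scatter, while an at least 1.4-fold lower number from compound 1 to compound 3 (0.16 log units; that floor lies within the scatter) is a floor that also lies within it. For compound 4 the step of a 1.0-fold higher number from compound 3 to compound 4 (0.01 log units; within the scatter) is therefore expected to be small and without a clear direction. Compound 4 is estimated at 14000 nM, within a range from 5000 nM to 40000 nM.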

Compound 4, half-maximal inhibitory concentration: > 20000 nM
Compound 4: no number, only a limit; the forecaster's own chance of this, stated with the estimate: 30%; middle value at least 1.4-fold (0.15 log units) away from the limit.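

In this assay compound 4 gives > 20000 nM, which is a limit and not a number. The first change made on the aromatic ring itself, para to a large group, gives an at least 1.4-fold higher number from compound 3 to compound 4 (0.16 log units; that floor lies within the scatter), so cyano and bromo are not separated here, whereas the exchange of the whole aromatic group gives an at least 2.2-fold higher number from compound 2 to compound 4 (0.35 log units; beyond the scatter), a step that is readable beyond the scatter, as the exchange for 4-bromophenyl was not. The step from compound 1 to compound 4 cannot be read, as both values are limits: the limit of > 20000 nM in this assay, at which 2 of the 4 values shown sit.

Open, on these data alone, is how far compound 4 lies past the limit, and so whether cyano and bromo differ at all in this assay. Also open, as far as these compounds go, is how an amine or a carboxylic acid at the same place on the aromatic ring, or a shorter chain on the shared core, would shift the number.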